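Chloropyrimidine amide replaces methoxyphenyl in a flavonol series

The source may hold more compounds than are shown below. What is called first, only, known or untested is meant among the compounds shown, and "the series" means these compounds.

Three amides built on one shared core have been measured in a functional assay on HepG2 cells (Homo sapiens) for antiproliferative activity, read by CCK-8 assay, with a stated time of 72 h; on this read-out higher numbers stand for weaker inhibition and lower numbers for stronger inhibition. Compound 1 `COc1ccc(C(=O)Nc2cccc(-c3oc4cc(-c5ccc(F)cc5)ccc4c(=O)c3O)c2)cc1` gives 8420 nM in this assay. Compound 3 `Cc1cc(C)cc(C(=O)Nc2cccc(-c3oc4cc(-c5ccc(F)cc5)ccc4c(=O)c3O)c2)c1` gives 13400 nM, and the step of a 1.6-fold higher number from compound 1 to compound 3 (0.20 log units; within the scatter) stays within the scatter, so the two numbers cannot be ordered. For compound 2 `O=C(Nc1cccc(-c2oc3cc(-c4ccc(F)cc4)ccc3c(=O)c2O)c1)c1ccc(Br)cc1F` the assay reports only a limit, > 100000 nM. Compound 1 therefore stands at the lower of the two actual numbers, with one further value being a limit (the limit of > 100000 nM in this assay, at which 1 of the 3 values shown sits).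

The two measured steps away from compound 1 differ sharply: an at least 11-fold higher number from compound 1 to compound 2 (1.07 log units; beyond the scatter) against a 1.6-fold higher number from compound 1 to compound 3 (0.20 log units; within the scatter), and an at least 7.4-fold lower number from compound 2 to compound 3 (0.87 log units; beyond the scatter) confirms the gap. A halogenated aryl on the carbonyl carbon thus coincided with a large loss, while a dimethylated one did not.

Compound 4 `O=C(Nc1cccc(-c2oc3cc(-c4ccc(F)cc4)ccc3c(=O)c2O)c1)c1cnc(Cl)nc1Cl` carries a second halogenated ring on that same carbonyl carbon: 2,4-dichloropyrimidin-5-yl in place of 4-methoxyphenyl on a carbonyl carbon. For the measured compounds named here, the nearest precedent is compound 2, whose step an at least 11-fold higher number from compound 1 to compound 2 (1.07 log units; beyond the scatter) was large and upward. Compound 4 is accordingly expected to show a weaker result than compound 1, a 3.6-fold higher number from compound 1 to compound 4 (0.55 log units; beyond the scatter), though the size is uncertain. The estimate for compound 4 in this assay is 30000 nM, expected to fall between 8000 nM and 100000 nM.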

Compound 4, half-maximal inhibitory concentration: > 100000 nM
Compound 4 gave a limit, no number; the forecaster's own chance of this, stated with the estimate: 35%; at least 3.3-fold (0.52 log units) between middle value and limit.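

Replacing the methoxyphenyl ring with a chlorinated pyrimidine gives an at least 11-fold higher number from compound 1 to compound 4 (1.07 log units; beyond the scatter), and replacing the dimethylphenyl ring gives an at least 7.4-fold higher number from compound 3 to compound 4 (0.87 log units; beyond the scatter), so the large loss at this carbonyl carbon is no longer tied to the 4-bromo-2-fluorophenyl ring of compound 2 alone. Across these four compounds, both halogenated rings now coincide with weak results, and neither the 4-methoxyphenyl nor the 3,5-dimethylphenyl amide goes against that pattern. Compound 2 and compound 4 share a limit rather than a number, so the step between them cannot be read: the limit of > 100000 nM in this assay, at which 2 of the 4 values shown sit.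

The shown compounds do not separate the contribution of the chlorine atoms from that of the ring nitrogens. An unsubstituted pyrimidin-5-yl ring or a 4-chlorophenyl ring on the same carbonyl carbon would address that question.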